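Para substituent change on the arylidene ring, next entry

A few compounds are considered here, and "the series" means these few. Any claim that something is new, unique, unknown or untested is made for them only; others in the source may bear on it.

Compound 1 `COC(=O)c1cc(NC2=NC(=O)/C(=C/c3ccc(C)cc3)S2)ccc1O` gives 1050 nM in an ADME assay on F180 cells (Homo sapiens) for cytotoxicity, read by sulforhodamine B assay, with a stated time of 48 h; a lower number here means a stronger inhibitor, a higher number a weaker inhibitor. Going by the values given here, compound 2 `COC(=O)c1cc(NC2=NC(=O)/C(=C/c3ccc(Br)cc3)S2)ccc1O` gives 10000 nM in this assay and stands highest of the two numbers measured so far; the step of a 9.5-fold higher number from compound 1 to compound 2 (0.98 log units; beyond the scatter) is the only measured step. Compound 3 `COC(=O)c1cc(NC2=NC(=O)/C(=C/c3ccc(N(C)C)cc3)S2)ccc1O` carries dimethylamino in place of bromo on an aromatic carbon. Among the compounds with values here, only the step from compound 1 to compound 2 bears on this change, since it altered the same position, and it was modest yet beyond the scatter. Within the data shown here, no dimethylamino analogue has been measured, so the direction rests on that single step alone. The expected step is a 2.9-fold lower number from compound 2 to compound 3 (0.46 log units; beyond the scatter), a modest move lower with wide uncertainty. Compound 3 is therefore estimated at 3500 nM, within 800 nM to 15000 nM.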

Compound 3, half-maximal inhibitory concentration: 940 nM
For compound 3 the middle estimate is 3.7-fold (0.57 log units) above the measured one; measured number inside the range.
By their numbers in this assay, from the lowest: compounds 3 and 1 (each within the scatter of the next); then compound 2.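

In this assay, dimethylamino in place of bromo gives an 11-fold lower number from compound 2 to compound 3 (1.03 log units; beyond the scatter), so the replacement of bromo at this position can return the number to the level seen with methyl. Dimethylamino in place of methyl gives a 1.1-fold lower number from compound 1 to compound 3 (0.05 log units; within the scatter), which leaves these two groups indistinguishable here and bromo as the only one of the three set apart. No evidence on any property of these groups accompanies this separation.

Going by these compounds, whether chloro or fluoro would track bromo remains open. So does whether a primary amine or a carboxylic acid would track dimethylamino.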